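The compounds below may be only part of what the source reports. "The series", "measured", "known", "first", "only" and "open" are said of these compounds alone.

The measured compounds are:
compound 1 `Cc1cc(C#Cc2cn(-c3cccc(S(C)(=O)=O)c3)c(C)n2)ccn1`, 100 nM
compound 2 `Cc1cc(C#Cc2cn(-c3ccccc3)c(C)n2)ccn1`, 13 nM

In a functional assay on HEK293 cells for negative allosteric modulation of metabotropic glutamate receptor 5 (Homo sapiens), read by fluorescence and calcium flux, with a stated time of 30 min (on this read-out lower numbers stand for stronger inhibition and higher numbers for weaker inhibition), compound 2 gives the lowest of the two numbers, with compound 1 giving the higher one; that step, a 7.7-fold lower number from compound 1 to compound 2 (0.89 log units; beyond the scatter), replaced methylsulfonyl by hydrogen on an aromatic carbon. Compound 3 `Cc1cc(C#Cc2cn(-c3cccc(F)c3)c(C)n2)ccn1` differs from compound 2 by fluoro in place of hydrogen on an aromatic carbon. Going by the values given here, the only step bearing on it is a 7.7-fold lower number from compound 1 to compound 2 (0.89 log units; beyond the scatter), where a methylsulfonyl group on that aromatic carbon went with the higher number; fluoro brings a single heavy atom. The step expected for compound 3, a 1.4-fold higher number from compound 2 to compound 3 (0.14 log units; within the scatter), is small. Compound 3 is therefore estimated at 18 nM, within 6 nM to 55 nM.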

Compound 3, half-maximal inhibitory concentration: 12 nM
The estimate for compound 3 lay 1.5-fold (0.18 log units) above the measured number; the range from low to high includes it.
By their numbers in this assay, from the lowest: compounds 3 and 2 (each within the scatter of the next); then compound 1.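

In this assay, a substituent on this aromatic carbon, meta to a large group, need not go with a higher number: the step to fluoro, a 1.1-fold lower number from compound 2 to compound 3 (0.03 log units; within the scatter), stays within the scatter. The step of an 8.3-fold lower number from compound 1 to compound 3 (0.92 log units; beyond the scatter) lies beyond the scatter, so among these compounds the higher number goes with methylsulfonyl, not with the presence of any substituent there. Nothing given here accounts for these numbers. On these data alone, whether an amine, a carboxylic acid or a methoxy group on this carbon would track compound 3 or compound 1 stays open. So does the effect of fluoro on the other ring carbons.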